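The compounds below may be only part of what the source reports. "The series", "measured", "known", "first", "only" and "open" are said of these compounds alone.

Working notes on the series. Among the compounds with values here, in an in vitro ADME assay on microsomes from liver (Rattus norvegicus) for metabolic stability (on this read-out lower numbers stand for slow clearance and higher numbers for fast clearance), compound 3 `CC[C@H](C)[C@@H]1C(=O)N[C@H](C2Cc3ccccc3C2)C(=O)N1[C@@H](C(=O)N(C)C)c1ccc(C)nc1C` gives 1 mL.min-1.g-1, level with compound 1 `CC[C@H](C)[C@@H]1C(=O)N[C@H](C2Cc3ccccc3C2)C(=O)N1[C@@H](C(=O)N1CCOCC1)c1cnc(C)cc1C` at 1 mL.min-1.g-1, and these two share the lowest number so far. Compound 2 `Cc1ccc([C@H](C(=O)N(C)C)N2C(=O)[C@@H](C3Cc4ccccc4C3)NC(=O)[C@H]2CC(C)C)cn1` stands far higher at 3000 mL.min-1.g-1, well beyond the scatter.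

The next compound is compound 4 `CC[C@H](C)[C@@H]1C(=O)N[C@H](C2Cc3ccccc3C2)C(=O)N1[C@@H](C(=O)N(C)C)c1ccc(C)[n+]([O-])c1`, and its change from compound 3 is a group of 8 heavy atoms (6 carbon, 1 nitrogen, 1 oxygen; one six-membered aromatic ring with 1 hetero atom) in place of a group of 8 heavy atoms (7 carbon, 1 nitrogen; one six-membered aromatic ring with 1 hetero atom), on a saturated chain carbon bound to an amide-type nitrogen in a ring and a carbonyl carbon. The 2,6-dimethylpyridin-3-yl group leaves, and the incoming group has no common name. Within the data shown here, no measured pair isolates this change, so the size of the step in this assay cannot be read from the data. The high number of compound 2 gives a warning that this series can reach fast clearance, but it does not calibrate this step. A low number is still expected because compound 3 reads 1 mL.min-1.g-1. The expected outcome is a 3.0-fold higher number from compound 3 to compound 4 (0.48 log units; beyond the scatter), a modest rise that may not clear the scatter. For compound 4 the estimated value is 3 mL.min-1.g-1, with an expected range of 1 mL.min-1.g-1 to 15 mL.min-1.g-1.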

Compound 4, intrinsic clearance in microsomes: 1 mL.min-1.g-1
Estimate against measurement, compound 4: 3.0-fold (0.48 log units) above; the range from low to high includes it.
By their numbers in this assay, from the lowest: compounds 1, 3 and 4 (each within the scatter of the next); then compound 2.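

In this assay, within the data shown here, the exchange of the 2,6-dimethylpyridin-3-yl group for the incoming group, on a saturated chain carbon bound to an amide-type nitrogen in a ring and a carbonyl carbon, gives no change at the digits printed from compound 3 to compound 4 (within the scatter) and is the first step that can be read at this position. At this position, then, the read-out stays level across a swap that keeps the heavy-atom count and the donor and acceptor counts and puts an oxygen into the group. Nothing measured on hand accounts for this level result.

Still open, going by these compounds, is whether the same exchange would stay level on the background of compound 2, which stands at 3000 mL.min-1.g-1 in this assay. Also open, on these data alone, is how an aromatic ring carrying a carboxylic acid or a primary amine would read at this position.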